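The source may hold more compounds than are shown below. What is called first, only, known or untested is meant among the compounds shown, and "the series" means these compounds.

Working notes on the series. Among the measured compounds shown here, compound 1 `COc1cc(C)cc(-c2c(-c3ccnc(-c4ccc(N(C)C)cc4)c3)cnn2CC#N)c1` is one of two compounds measured so far in a functional assay on MDA-MB-468 cells (Homo sapiens) for cytotoxicity, read by sulforhodamine B assay, with a stated time of 48 h, tested at 1 uM; a higher number here means a weaker effect of the compound at the concentration tested, a lower number a stronger effect; in that assay compound 1 gives -57%. Compound 2 `Cc1cc(O)cc(-c2nn(CC#N)cc2-c2ccnc(-c3ccc(Oc4ccccc4)cc3)c2)c1` in this assay gives -62%. Compound 1 stands at the higher of the two numbers, but the gap to compound 2 lies within the usual scatter, so the two cannot be told apart on these data.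

Compound 3 `COc1cc(C)cc(-c2c(-c3ccnc(-c4ccc(C(C)=O)cc4)c3)cnn2CC#N)c1` is not yet measured in this assay. It differs from compound 1 in a single place: acetyl in place of dimethylamino on an aromatic carbon. For the measured compounds named here, no pair of measured compounds shows this kind of change, so there is no measured step to lean on; the only guide is the level of compound 1 itself.

With nothing in the data pointing one way, the step from compound 1 to compound 3 is expected to be small and is estimated at a number 12 percentage points higher from compound 1 to compound 3 (beyond the scatter), which may not exceed the scatter. Compound 3 is accordingly expected to read about -45% in this assay, with a range from -75% to -5%, the width reflecting the absence of any comparable measured step.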

Compound 3, a percentage reported as activity, at one concentration (the size of the read-out at that concentration, not a potency): -48%
Estimate against measurement, compound 3: 3 percentage points above, and the stated range covers the measured number.
By their numbers in this assay, from the lowest: compounds 2, 1 and 3 (each within the scatter of the next, the first and the last beyond it).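

In this assay, this position, on an aromatic carbon para to a large group, now has its first measured step: acetyl in place of dimethylamino gives a number 9 percentage points higher from compound 1 to compound 3 (within the scatter). Among the compounds shown here, the exchange of 4-(dimethylamino)phenyl for 4-acetylphenyl therefore cannot be told apart from no step at all on these data, and this position accepts either group without a separation that the scatter would allow to be read. No measurement at hand bears on a cause for this step.

Going by these compounds, whether a different kind of group at this position, such as a carboxylic acid, a primary amine or a longer alkyl chain, would move the read-out beyond the scatter remains open. Also open, on these data alone, is whether acetyl and dimethylamino would stay inseparable at other concentrations, since each compound here is read at a single concentration.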